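The source may hold more compounds than are shown below. What is called first, only, known or untested is meant among the compounds shown, and "the series" means these compounds.

Compound 2 `COc1cc2c(Oc3ccc(NC(=O)c4nn(-c5ccccc5Br)c(=O)c5ccccc45)cc3F)ccnc2cc1OCCCN1CCCC1` gives 1020 nM in a functional assay on MDA-MB-231 cells (Homo sapiens) for cytotoxicity, read by MTT assay, with a stated time of 72 h; on this read-out higher numbers stand for weaker inhibition and lower numbers for stronger inhibition. Among the compounds with values here, the only other compound measured, compound 1 `COc1cc2c(Oc3ccc(NC(=O)c4nn(-c5ccc(Br)cc5)c(=O)c5ccccc45)cc3F)ccnc2cc1OCCCN1CCCC1`, gives 1160 nM in this assay, and the two numbers lie within the scatter of each other: a 1.1-fold lower number from compound 1 to compound 2 (0.06 log units; within the scatter). Compound 3 `COc1cc2c(Oc3ccc(NC(=O)c4nn(-c5ccc([N+](=O)[O-])cc5)c(=O)c5ccccc45)cc3F)ccnc2cc1OCCCN1CCCC1` differs from compound 2 by 4-nitrophenyl in place of 2-bromophenyl on an aromatic nitrogen. Within the data shown here, no measured step exchanges a bromine for a nitro group; the one step recorded, a 1.1-fold lower number from compound 1 to compound 2 (0.06 log units; within the scatter), only moved the bromine on the same ring and stayed within the scatter, so it bears on this change weakly. Compound 3 is therefore expected to stay close to compound 2, with a step of a 1.1-fold higher number from compound 2 to compound 3 (0.03 log units; within the scatter), and its estimated value in this assay is 1100 nM, in the range 450 nM to 2700 nM.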

Compound 3, half-maximal inhibitory concentration: 2980 nM
The estimate for compound 3 lay 2.7-fold (0.43 log units) below the measured number; measured number above the stated range.
By their numbers in this assay, from the lowest: compounds 2 and 1 (each within the scatter of the next); then compound 3.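

Nitro in place of bromo on an aromatic carbon shows that this substituent matters in this assay even though moving the bromine did not: the change gives a 2.6-fold higher number from compound 1 to compound 3 (0.41 log units; beyond the scatter) and so weakens inhibition beyond the scatter. The exchange of 2-bromophenyl for 4-nitrophenyl on the aromatic nitrogen agrees with this, giving a 2.9-fold higher number from compound 2 to compound 3 (0.47 log units; beyond the scatter) as a similarly modest step. No measurement offered here accounts for this shift. From the compounds shown here alone, whether 2-nitrophenyl would match 4-nitrophenyl remains open, as does how an amine or a carboxylic acid on this ring would compare with nitro and bromo.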